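The compounds below may be only part of what the source reports. "The series", "measured", "known", "first", "only" and "open" are said of these compounds alone.

The study concerns three benzophenones measured in a functional assay on THP-1 cells (Homo sapiens) for inhibition, read by ELISA, with stated times of 30 min and 24 h, tested at 1 uM (on this read-out lower numbers stand for a weaker effect and higher numbers for a stronger effect at the one concentration tested), and a fourth that awaits measurement. Compound 1 `COc1cc(OC)c(C(=O)c2ccccc2F)c(O)c1CN1CCCC1` gives 15%, and compound 2 `COc1cc(OC)c(C(=O)c2ccccc2Br)c(O)c1CN1CCCCC1` gives 22%. Compound 3 `COc1cc(O)c(C(=O)c2ccccc2F)c(OC)c1`, which lacks the aminomethyl group of the other two, gives 11%. Among the three, compound 3 stands apart only from compound 2, beyond the scatter; against compound 1 the difference is within the scatter, as the step of a number 4 percentage points lower from compound 1 to compound 3 (within the scatter) shows.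

Compound 4 `COc1cc(OC)c(C(=O)c2ccccc2F)c(O)c1CN1CCCCC1` differs from compound 3 by (piperidin-1-yl)methyl in place of hydrogen on an aromatic carbon. Among the measured compounds shown here, the only measured step that bears on this change is the one from compound 1 to compound 3, the removal of the related (pyrrolidin-1-yl)methyl group, and it moved the number by an amount within the scatter. Compound 2, which carries the same (piperidin-1-yl)methyl group but a bromo rather than a fluoro substituent, sits somewhat higher than compound 3. A small upward step a number 6 percentage points higher from compound 3 to compound 4 (within the scatter) is therefore expected, not clearly beyond the scatter. Compound 4 is estimated at 17%, with a range from 5% to 30%.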

Compound 4, a percentage reported as activity, at one concentration (the size of the read-out at that concentration, not a potency): 18%
Estimate against measurement, compound 4: 1 percentage points below, within the range that was stated.
By their numbers in this assay, from the lowest: compounds 3, 1, 4 and 2 (each within the scatter of the next, the first and the last beyond it).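

With (piperidin-1-yl)methyl in place of hydrogen on the aromatic carbon ortho to a hydroxy group, this assay shows a number 7 percentage points higher from compound 3 to compound 4 (within the scatter), so this group, like the (pyrrolidin-1-yl)methyl group before it, does not separate from hydrogen at this position. Compound 4 also makes two further single changes readable: piperidin-1-yl in place of pyrrolidin-1-yl gives a number 3 percentage points higher from compound 1 to compound 4 (within the scatter), and fluoro in place of bromo gives a number 4 percentage points lower from compound 2 to compound 4 (within the scatter). Neither the choice of saturated ring nor that of halogen therefore stands out from the scatter at the one concentration tested.

Nothing given here accounts for these numbers. As far as these compounds go, whether a morpholin-4-ylmethyl or a dimethylaminomethyl group at this position, or a chloro group in place of the fluoro, would produce a step beyond the scatter remains open.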